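The source may report more compounds than this note shows. Statements on the series, on what has been measured and on what is new or still open speak of the compounds shown alone.

In a functional assay on MCF7 cells (Homo sapiens) for antiproliferative activity, read by CellTiter-Glo, with a stated time of 5 days (a higher number here means a weaker inhibitor, a lower number a stronger inhibitor), compound 3 (`N#Cc1cc(Cl)ccc1/C(=C(\c1ccc(/C=C/C(=O)O)cc1)c1ccc(-c2cncs2)cc1)C1CCC1`) reads 4.3 nM and lies within the scatter of compound 2 (`O=C(O)/C=C/c1ccc(/C(=C(\c2ccc(F)cc2Cl)C2CCC2)c2ccc(-c3cncs3)cc2)cc1`), at 4.2 nM and of compound 1 (`O=C(O)/C=C/c1ccc(/C(=C(\c2ncc(C(F)(F)F)cc2Cl)C2CCC2)c2ccc3scnc3c2)cc1`), at 2.9 nM here. Compound 4 (`O=C(O)/C=C/c1ccc(/C(=C(\c2ncc(C(F)(F)F)cc2Cl)C2CCC2)c2ccc(-c3cncs3)cc2)cc1`) has 3-chloro-5-(trifluoromethyl)pyridin-2-yl in place of 4-chloro-2-cyanophenyl on a double-bonded chain carbon bound to a double-bonded chain carbon and a saturated ring carbon. Within the data shown here, the only measured step at this place was a 1.0-fold higher number from compound 2 to compound 3 (0.01 log units; within the scatter) and stayed within the scatter. Compound 1 already carries the entering group, on a different core, and reads 2.9 nM in this assay. No step beyond the scatter is therefore expected, and the estimated step is a 1.2-fold lower number from compound 3 to compound 4 (0.09 log units; within the scatter) here. The expected value for compound 4 is 3.5 nM (estimated range 1.5 nM to 8 nM).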

Compound 4, half-maximal inhibitory concentration: 7.3 nM
Estimate against measurement, compound 4: 2.1-fold (0.32 log units) below; the measured number falls inside the stated range.
By their numbers in this assay, from the lowest: compounds 1, 2, 3 and 4 (each within the scatter of the next, the first and the last beyond it).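

In this assay, the group on a double-bonded chain carbon bound to a double-bonded chain carbon and a saturated ring carbon accepts 3-chloro-5-(trifluoromethyl)pyridin-2-yl, with a 1.7-fold higher number from compound 3 to compound 4 (0.23 log units; within the scatter) and a 1.7-fold higher number from compound 2 to compound 4 (0.24 log units; within the scatter) both within the scatter. Among these compounds, the only step beyond the scatter lies at another place, where 4-(1,3-thiazol-5-yl)phenyl in place of 1,3-benzothiazol-5-yl gives a 2.5-fold higher number from compound 1 to compound 4 (0.40 log units; beyond the scatter) as a modest step. From the compounds shown here alone, whether an amine or a methoxy group on this ring would stay within the scatter remains open. No evidence on a cause accompanies these steps.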